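Removing the propargyl group from compound 2

The source may hold more compounds than are shown below. What is called first, only, known or untested is meant among the compounds shown, and "the series" means these compounds.

Measured compounds:
- compound 1, `C#CCNCc1cc2ccccc2n1C`: 3830 nM
- compound 2, `C#CCN(Cc1ccccc1)Cc1cc2ccccc2n1C`: 60000 nM
- compound 3, `C#CCN(C)Cc1cc2ccccc2n1C`: 3 nM

In an assay on isolated protein for inhibition of Amine oxidase [flavin-containing] B (Rattus norvegicus) (on this read-out lower numbers stand for stronger inhibition and higher numbers for weaker inhibition), compound 2 stands at the highest number of the three, which means it is the weakest inhibitor shown. The nearest measured compound is compound 1, and the step of a 16-fold higher number from compound 1 to compound 2 (1.19 log units; beyond the scatter) shows the benzyl group on the amine nitrogen costing a lot. The gap to compound 3 is far larger still, as the step of a 20000-fold lower number from compound 2 to compound 3 (4.30 log units; beyond the scatter) shows, and the step of a 1300-fold lower number from compound 1 to compound 3 (3.11 log units; beyond the scatter) shows how much a methyl on that same nitrogen helps.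

Compound 4, `Cn1c(CNCc2ccccc2)cc2ccccc21`, keeps the benzyl group but loses the propargyl chain: hydrogen in place of propargyl on an amine nitrogen. Among the measured compounds shown here, none of the measured steps touches the propargyl group; all three change the other substituent on the amine nitrogen, so there is no direct precedent for this change, and the expectation rests only on the weak starting point of compound 2. Compound 4 is expected to give about 150000 nM, within a range of 30000 nM to 800000 nM. The expected step of a 2.5-fold higher number from compound 2 to compound 4 (0.40 log units; beyond the scatter) is a modest further weakening, with a real possibility that the assay only reports a limit.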

Compound 4, inhibition constant: 48000 nM
Compound 4: middle estimate off by 3.1-fold (0.49 log units), on the high side; measured number inside the range.
By their numbers in this assay, from the lowest: compound 3; then compound 1; then compounds 4 and 2 (each within the scatter of the next).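

In this assay, among the compounds shown here, hydrogen in place of propargyl on the amine nitrogen gives a 1.3-fold lower number from compound 2 to compound 4 (0.10 log units; within the scatter), so where benzyl is the other substituent on that nitrogen, the propargyl group makes no readable difference; the earlier steps could not show this, as each of them changed a different substituent. The picture differs when the amine nitrogen also carries a hydrogen: phenyl in place of ethynyl on the saturated chain carbon gives a 13-fold higher number from compound 1 to compound 4 (1.10 log units; beyond the scatter), so the propargyl-bearing amine keeps a clear edge over the benzyl-bearing one. No measurement shown here accounts for this difference between the two settings.

From the compounds shown here alone, it remains open whether hydrogen in place of propargyl would also leave the number within the scatter when methyl is the other substituent on the nitrogen, as in compound 3 at 3 nM. Also open, going by these compounds, is whether an ethyl group or a longer chain on that nitrogen, or an allyl group in place of propargyl, would keep a number as low as that of compound 3.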